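From compound 2 to compound 3: a carboxy chain change

This account rests on a few compounds, and the source may have more. Where it says the series, first, only, none or still open, it means among the compounds named here.

Measured in a functional assay on PC-3 cells (Homo sapiens) for antiproliferative activity, read by MTT assay, with a stated time of 72 h; a higher number here means a weaker inhibitor, a lower number a stronger inhibitor:
- compound 1 `O=C(CCCCCOc1ccc2cc1COC/C=C/COCc1cccc(c1)-c1ccnc(n1)N2)NO`: 8110 nM
- compound 2 `O=C(O)CCCCCCCOc1ccc2cc1COC/C=C/COCc1cccc(c1)-c1ccnc(n1)N2`: 22800 nM

Among the measured compounds shown here, of the two compounds measured so far, compound 2 stands highest, with 22800 nM in this assay, and so is the weaker inhibitor. Compound 3 `O=C(O)CCCCCCOc1ccc2cc1COC/C=C/COCc1cccc(c1)-c1ccnc(n1)N2` departs from compound 2 through (carboxy in place of carboxymethyl on a saturated chain carbon, six bonds along the chain from an oxygen on an aromatic ring), with carboxy in place of carboxymethyl on a saturated chain carbon, six bonds along the chain from an oxygen on an aromatic ring. For the measured compounds named here, the only measured step is a 2.8-fold higher number from compound 1 to compound 2 (0.45 log units; beyond the scatter). Going by the values given here, that modest step concerns a different change at the chain end, so it bears only loosely on this one, and no measured pair shows this change alone. No shift beyond the scatter is therefore expected, and no direction can be firmly expected either. The estimated change is a 1.1-fold lower number from compound 2 to compound 3 (0.06 log units; within the scatter). For compound 3 the estimated value is 20000 nM, with an expected range of 9500 nM to 42000 nM.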

Compound 3, half-maximal inhibitory concentration: 8760 nM
Estimate against measurement, compound 3: 2.3-fold (0.36 log units) above, outside the stated range (below it).
By their numbers in this assay, from the lowest: compounds 1 and 3 (each within the scatter of the next); then compound 2.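

In this assay, carboxy in place of carboxymethyl gives a 2.6-fold lower number from compound 2 to compound 3 (0.42 log units; beyond the scatter), so at this place, six bonds along the chain from an oxygen on an aromatic ring, the length of the chain alone moves the number beyond the scatter while the carboxylic acid end stays the same. The gap between compound 1 and compound 2 therefore does not follow from the carboxylic acid end as such: carboxymethyl in place of hydroxycarbamoyl gives a 1.1-fold higher number from compound 1 to compound 3 (0.03 log units; within the scatter), which lies within the scatter. Nothing at hand accounts for the effect of this shortening.

As far as these compounds go, whether a still shorter carboxylic acid chain would continue this trend remains open. So does how a hydroxycarbamoyl group on a longer chain, or an amine at the chain end, would compare.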